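From Thiomorpholine to Pyrrolidine on a Thiocarbonyl Carbon

The source may hold more compounds than are shown below. What is called first, only, known or untested is meant among the compounds shown, and "the series" means these compounds.

Measured compounds:
compound 1 `Cc1ccnc(/C(N)=N/NC(=S)N2CCSCC2)c1`: 6900 nM
compound 2 `Cc1cccc(/C(N)=N/NC(=S)N2CCCCCC2)n1`: 54700 nM

Of the compounds shown here, two have been tested in a functional assay on MCF7 cells (Homo sapiens) for cytotoxicity, read by MTT assay, with a stated time of 72 h; on this read-out higher numbers stand for weaker inhibition and lower numbers for stronger inhibition. Compound 1 gives 6900 nM, the lower of the two numbers, and compound 2 gives 54700 nM, a gap that lies beyond the usual scatter of this assay. Compound 2 differs from compound 1 at more than one place, so nothing can be read from that pair about any single change.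

Compound 3 `Cc1ccnc(/C(N)=N/NC(=S)N2CCCC2)c1` differs from compound 1 in one place only: pyrrolidin-1-yl in place of thiomorpholin-4-yl on a thiocarbonyl carbon. For the measured compounds named here, no measured pair shows this change, so any expectation rests on compound 1 alone, with the ring swap treated as an open question. The step from compound 1 to compound 3 is estimated to be a 1.4-fold higher number from compound 1 to compound 3 (0.16 log units; within the scatter), with a direction that cannot be called beyond the scatter on present data. Compound 3 is therefore expected to give about 10000 nM in this assay, with a range from 2500 nM to 40000 nM.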

Compound 3, half-maximal inhibitory concentration: 1200 nM
Compound 3: middle estimate off by 8.3-fold (0.92 log units), on the high side; the whole stated range lies above it.
By their numbers in this assay, from the lowest: compound 3; then compound 1; then compound 2.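

In this assay, the group on the thiocarbonyl carbon clearly matters: with the rest of the molecule unchanged, pyrrolidin-1-yl in place of thiomorpholin-4-yl gives a 5.8-fold lower number from compound 1 to compound 3 (0.76 log units; beyond the scatter). For the compounds shown here, this is the first comparison here that differs in one place only, so it is the first direct sign that this position responds to a change of ring, and the step lies beyond the usual scatter. No measurement at hand accounts for the step.

The compounds shown leave open whether ring size, the sulfur in thiomorpholin-4-yl, or both together lie behind this difference. Piperidin-1-yl, a six-membered ring without sulfur, and morpholin-4-yl, a six-membered ring with oxygen instead of sulfur, would each bear on that question.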